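This account rests on a few compounds, and the source may have more. Where it says the series, first, only, none or still open, it means among the compounds named here.

Three compounds share one core. Compound 1 `COc1cc(OC)cc(-c2ccc3c(c2)C(CC(=O)OCC2CC2)C(C(=O)OCC2CC2)=C(N)O3)c1` gives 6700 nM in a functional assay on HL-60 cells (Homo sapiens) for cytotoxicity, read by CellTiter-Blue, with a stated time of 48 h; on this read-out higher numbers stand for weaker inhibition and lower numbers for stronger inhibition. Compound 2 `CCOC(=O)CC1C(C#N)=C(N)Oc2ccc(-c3cc(OC)cc(OC)c3)cc21` gives 19600 nM in this assay, and compound 3 `CCOC(=O)CC1C(C(=O)OCC)=C(N)Oc2ccc(-c3ccc(F)cc3)cc21` gives 72100 nM in this assay. Compound 3 thus carries the highest number of the three: compound 2 sits closest to it and compound 1 furthest away, both gaps beyond the scatter. Compound 4 `CCOC(=O)CC1C(C(=O)OCC)=C(N)Oc2ccc(-c3ccnc(OC)c3)cc21` is not yet measured. It differs from compound 3 in one place: 2-methoxypyridin-4-yl in place of 4-fluorophenyl on an aromatic carbon. Among the compounds with values here, compound 1 and compound 2, which also carry methoxy groups, show lower numbers than compound 3, but each differs from compound 3 in more than one place, so no step to compound 4 can be read from them. A small move toward a lower number is expected, a 2.1-fold lower number from compound 3 to compound 4 (0.31 log units; beyond the scatter), near the edge of the scatter. Compound 4 is estimated at 35000 nM, between 12000 nM and 100000 nM.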

Compound 4, half-maximal inhibitory concentration: 10200 nM
For compound 4 the middle estimate is 3.4-fold (0.54 log units) above the measured one, outside the stated range (below it).
By their numbers in this assay, from the lowest: compounds 1, 4 and 2 (each within the scatter of the next, the first and the last beyond it); then compound 3.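

In this assay, within the data shown here, 2-methoxypyridin-4-yl in place of 4-fluorophenyl gives a 7.1-fold lower number from compound 3 to compound 4 (0.85 log units; beyond the scatter) and is the first single-place step here, so the group on this aromatic carbon clearly affects the read-out. The new group brings hydrogen-bond acceptors that 4-fluorophenyl lacks, but one step cannot separate the ring nitrogen from the methoxy group. No measurement at hand explains this step. Compound 1 and compound 2 differ from the others in more than one place, so their steps cannot be read. As far as these compounds go, how a pyridine without the methoxy, or with an amine in its place, would read remains open.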